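Fused Bicyclic Ring in Place of Cyanopyrazole

The source may hold more compounds than are shown below. What is called first, only, known or untested is meant among the compounds shown, and "the series" means these compounds.

Measured so far in an assay on cells for displacement of a labelled ligand from Glucagon receptor (Homo sapiens), in the presence of a further agent that is not named here; on this read-out lower numbers stand for stronger inhibition and higher numbers for weaker inhibition:
compound 1, `CCC(Oc1ccc(-n2cc(C(F)(F)F)cn2)cc1)c1ccc(C(=O)NCCC(=O)O)cc1`, gives 1400 nM
compound 2, `CCCC(Oc1ccc(-n2cc(C#N)cn2)cc1)c1ccc(C(=O)NCCC(=O)O)cc1`, gives 4100 nM

Of these two numbers, compound 2 stands at the higher one; compound 1 has the lower number, and the gap between them is beyond the usual scatter of this assay. Compound 3, `CCCC(Oc1ccc(-n2cc3c(n2)CCCC3)cc1)c1ccc(C(=O)NCCC(=O)O)cc1`, has not yet been measured. It differs from compound 2 in one place: a group of 9 heavy atoms (7 carbon, 2 nitrogen; one five-membered aromatic ring with 2 hetero atoms, one six-membered non-aromatic ring of carbon only) in place of a group of 7 heavy atoms (4 carbon, 3 nitrogen; one five-membered aromatic ring with 2 hetero atoms), on an aromatic carbon. Going by the values given here, no step between measured compounds isolates this change, so there is no measured precedent for how the fused bicyclic group compares with the cyano-bearing pyrazole. The expectation is a modest step in a 2.1-fold lower number from compound 2 to compound 3 (0.31 log units; beyond the scatter) toward a lower number, though it may not exceed the scatter. Compound 3 is therefore estimated at 2000 nM, with a range from 500 nM to 8000 nM.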

Compound 3, inhibition constant: 690 nM
Compound 3: the middle estimate sits 2.9-fold (0.46 log units) above what was measured, and the stated range covers the measured number.
By their numbers in this assay, from the lowest: compound 3; then compound 1; then compound 2.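

In this assay, going by these compounds alone, the step of a 5.9-fold lower number from compound 2 to compound 3 (0.77 log units; beyond the scatter) is the first measured change at this position, on an aromatic carbon para to a large group. It shows that the 4-cyano-1H-pyrazol-1-yl group is not required here: a larger group with a six-membered carbon ring fused to the pyrazole and no nitrile gives a lower number, and the step is beyond the scatter. No measurement shown here explains this difference.

Two things changed together, the nitrile left and the carbon ring arrived, so the step cannot be divided between them. Going by these compounds, it remains open how an unsubstituted pyrazole would compare, or a fused ring carrying an amine or an ether oxygen, and compound 1 differs from compound 3 in more than one place, so it does not settle the trifluoromethyl group's standing.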